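Compound 3 to compound 4: benzyloxycarbonyl to methoxycarbonyl

This account rests on a few compounds, and the source may have more. Where it says the series, first, only, none or still open, it means among the compounds named here.

Measured in a functional assay on MT4 cells (Homo sapiens); on this read-out lower numbers stand for higher toxicity in this test and higher numbers for lower toxicity in this test:
- compound 1 `C=C(C)C(=O)NC(=O)NC1=CS(=O)(=O)O[C@@]12[C@@H](CO[Si](C)(C)C(C)(C)C)O[C@@H](n1cc(C)c(=O)n(C)c1=O)[C@@H]2O[Si](C)(C)C(C)(C)C`: 1190 nM
- compound 2 `COC(=O)C(=O)CNC1=CS(=O)(=O)O[C@@]12[C@@H](CO[Si](C)(C)C(C)(C)C)O[C@@H](n1cc(C)c(=O)n(C)c1=O)[C@@H]2O[Si](C)(C)C(C)(C)C`: 10300 nM
- compound 3 `Cc1cn([C@@H]2O[C@H](CO[Si](C)(C)C(C)(C)C)[C@@]3(OS(=O)(=O)C=C3NCCC(=O)OCc3ccccc3)[C@H]2O[Si](C)(C)C(C)(C)C)c(=O)n(C)c1=O`: > 250000 nM (a limit)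

Compound 3 holds the highest reading of the three. Compound 3 stands at > 250000 nM, which is a limit of the assay and not a number.

The change to compound 4 `COC(=O)CCNC1=CS(=O)(=O)O[C@@]12[C@@H](CO[Si](C)(C)C(C)(C)C)O[C@@H](n1cc(C)c(=O)n(C)c1=O)[C@@H]2O[Si](C)(C)C(C)(C)C` is hydrogen in place of phenyl on a saturated chain carbon bound to an oxygen next to a carbonyl group. In words, this is hydrogen in place of phenyl on a saturated chain carbon bound to an oxygen next to a carbonyl group, which reads as benzyloxycarbonyl to methoxycarbonyl.

Within the data shown here, no measured step isolates this change. The nearest measured step is an at least 24-fold higher number from compound 2 to compound 3 (1.38 log units; beyond the scatter), and it also alters the chain itself. The other two steps, an 8.7-fold higher number from compound 1 to compound 2 (0.94 log units; beyond the scatter) and an at least 210-fold higher number from compound 1 to compound 3 (2.32 log units; beyond the scatter), replace the whole substituent on the amine nitrogen and bear on the question only loosely.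

Compound 2, at 10300 nM, carries the methoxycarbonyl group that compound 4 gains, so a moderate move towards lower numbers in this assay is expected. The reading of compound 4 may still stay at the same limit as compound 3. The expected step is an at least 3.5-fold lower number from compound 3 to compound 4 (0.55 log units; beyond the scatter). For compound 4 the estimate is 70000 nM, with an expected range from 15000 nM to 250000 nM.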

Compound 4, half-maximal cytotoxic concentration: > 250000 nM
Compound 4 ended at the assay's limit; the forecaster's own chance of this, stated with the estimate: 35%; middle value at least 3.5-fold (0.55 log units) away from the limit.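

In this assay compound 4 gives > 250000 nM, which is a limit of the assay and not a number, and the same holds for compound 3, so the step between them, hydrogen in place of phenyl, cannot be read: the limit of > 250000 nM in this assay, at which 2 of the 4 values shown sit.

The new information lies in the comparison with compound 2, which already carries methoxycarbonyl. The step of an at least 24-fold higher number from compound 2 to compound 4 (1.38 log units; beyond the scatter) keeps that group and changes only (methoxycarbonyl)carbonyl to (methoxycarbonyl)methyl, so among these compounds methoxycarbonyl does not go with the lower number on its own, and the chain change that was mixed into the step to compound 3 now stands apart from the loss of phenyl. The step of an at least 210-fold higher number from compound 1 to compound 4 (2.32 log units; beyond the scatter) replaces the whole substituent on the amine nitrogen and ends at the limit, as the step from compound 1 to compound 3 does.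

As far as these compounds go, how far compound 3 and compound 4 lie from each other beyond the limit stays open. Also open, from the compounds shown here alone, is whether a carboxylic acid in place of the ester, or a longer chain on the amine nitrogen, would bring the reading back under the limit.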